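Phenylpiperazine replacement in the shared-core series: growth inhibition

The source may report more compounds than this note shows. Statements on the series, on what has been measured and on what is new or still open speak of the compounds shown alone.

Compound 1, `NNC(=O)c1c(NC(=O)NS(=O)(=O)c2ccccc2)sc2c1CCCCC2`, sits at the assay limit in a functional assay on EKVX cells (Homo sapiens) for inhibition, with a stated time of 48 h (a lower number here means a stronger inhibitor of growth, a higher number a weaker inhibitor of growth), giving > 100000 nM. Compound 2, `O=C(Nc1sc2c(c1C(=O)NNc1ccccc1)CCCCC2)NS(=O)(=O)c1ccccc1`, likewise sits at the limit, giving > 100000 nM. Compound 3, `O=C(Nc1sc2c(c1C(=O)NNc1ccc(Cl)cc1)CCCCC2)NS(=O)(=O)c1ccccc1`, also sits at the limit, giving > 100000 nM.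

Compound 3 therefore stands nowhere readable on these numbers: its value is a limit and not a number, and the two further values shown are limits as well, all three sitting at the limit of > 100000 nM in this assay, at which 3 of the 3 values shown sit. The steps from compound 1 and compound 2 to compound 3 are a step that the two limits leave unreadable from compound 1 to compound 3 and a step that the two limits leave unreadable from compound 2 to compound 3; neither has a readable size, and the step that the two limits leave unreadable from compound 1 to compound 2 is equally unreadable.

Compound 4, `O=C(Nc1sc2c(c1C(=O)N1CCN(c3ccccc3)CC1)CCCCC2)NS(=O)(=O)c1ccccc1`, differs from compound 3 as follows: 4-phenylpiperazin-1-yl in place of ((4-chlorophenyl)amino)amino on a carbonyl carbon. Within the data shown here, no measured step bears a readable size on this change, so no direction can be drawn from the series. Among the measured compounds shown here, the only information is that every measured compound sits at the limit in this assay, and compound 4 keeps the core and the acyl-sulfonylurea part unchanged.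

Compound 4 is therefore expected to give 100000 nM in this assay, with an estimated range from 20000 nM to 300000 nM. The step from compound 3 to compound 4 is expected to be a number no higher from compound 3 to compound 4 (the limit leaves the size open).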

Compound 4, concentration for 50% growth inhibition: > 100000 nM
Compound 4: only a limit was reported; the forecaster's own chance of this, stated with the estimate: 75%; the middle value sits exactly at the limit.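

In this assay compound 4 gives > 100000 nM, which is a limit and not a number. No step among compound 1, compound 2, compound 3 and compound 4 can be read, as all share one limit: the limit of > 100000 nM in this assay, at which 4 of the 4 values shown sit.

The compounds shown leave open how the groups on the carbonyl carbon, aminoamino through 4-phenylpiperazin-1-yl, rank in growth inhibition.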